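Swapping the Dimethylamino Group of a Chalcone for Chlorine

A few compounds are considered here, and "the series" means these few. Any claim that something is new, unique, unknown or untested is made for them only; others in the source may bear on it.

Compound 1, `COc1ccc(C(=O)/C=C/c2ccc(N(C)C)cc2)c2c1C=CC(C)(C)O2`: 570 nM
Compound 2, `COc1ccc(C(=O)/C=C/c2ccc(N(c3ccccc3)c3ccccc3)cc2)c2c1C=CC(C)(C)O2`: > 10000 nM

Both compounds were tested in a functional assay on SW-620 cells (Homo sapiens) for antiproliferative activity, read by MTT assay, with a stated time of 24 h; on this read-out lower numbers stand for stronger inhibition and higher numbers for weaker inhibition. Going by the values given here, compound 1 gives 570 nM, and this is the only actual number among the values shown. For compound 2 the result is > 10000 nM, which is a limit of the assay and not a number. One of the two values shown therefore sits at the limit of > 10000 nM in this assay, at which 1 of the 2 values shown sits. Among the compounds with values here, compound 1 and compound 2 differ in more than one place, so no single step between them can be read.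

The next compound, compound 3, is `COc1ccc(C(=O)/C=C/c2ccc(Cl)cc2)c2c1C=CC(C)(C)O2`. It differs from compound 1 by chloro in place of dimethylamino on an aromatic carbon. No measured step of this kind exists among the compounds shown, so the size of the change can only be estimated. The expectation is a loss of potency beyond the usual scatter, that is, a step of a 5.3-fold higher number from compound 1 to compound 3 (0.72 log units; beyond the scatter) in this assay. On that basis compound 3 is expected to give about 3000 nM, with a likely range from 800 nM to 15000 nM.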

Compound 3, half-maximal inhibitory concentration: > 10000 nM
Compound 3 ended at the assay's limit (the forecaster's own chance of this, stated with the estimate: 25%); middle value at least 3.3-fold (0.52 log units) away from the limit.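

Going by these compounds alone, the step shows that this position does not tolerate every group: chloro in place of dimethylamino on an aromatic carbon gives an at least 17-fold higher number from compound 1 to compound 3 (1.24 log units; beyond the scatter) in this assay, the first change in a single place that can be read. The value of compound 3, > 10000 nM, is a limit of the assay and not a number. The result ties the measurable activity of compound 1 to the group at this position, while most of the compounds shown now sit at the end of the measurable scale: the limit of > 10000 nM in this assay, at which 2 of the 3 values shown sit.

Chloro replaces the nitrogen and both of its methyl groups in a single step, so it remains open whether the loss follows from removing the nitrogen or from some other difference between the two groups. A plain amino group, a diethylamino group or a pyrrolidine ring at the same place could separate these possibilities, and the compounds shown give no reason for the loss.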